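Dropping the Ring Methyl: Compound 3 to Compound 4

The source may hold more compounds than are shown below. What is called first, only, known or untested is meant among the compounds shown, and "the series" means these compounds.

Three measured compounds share one core and differ only in the group on the amide-type nitrogen. Compound 1 `Cc1ccc2[nH]c(C(=O)N[C@H]3CN(S(=O)(=O)c4ccccc4)C[C@@H]3C(=O)NCCN(C)C)cc2c1` in an ADME assay on cells (Hepatocyte, Rattus norvegicus) for metabolic stability (a higher number here means faster removal of the compound, a lower number slower removal), gives 16 uL/min. Compound 2 `Cc1ccc2[nH]c(C(=O)N[C@H]3CN(S(=O)(=O)c4ccccc4)C[C@@H]3C(=O)NC[C@H]3CCCN3)cc2c1` gives 10 uL/min, and compound 3 `Cc1ccc2[nH]c(C(=O)N[C@H]3CN(S(=O)(=O)c4ccccc4)C[C@@H]3C(=O)N[C@@H]3CCCN(C)C3)cc2c1` gives 23 uL/min. Compound 3 shows the highest of the three numbers, yet its gap to compound 1 is within the scatter a 1.4-fold higher number from compound 1 to compound 3 (0.16 log units; within the scatter), while its gap to compound 2 is beyond it a 2.3-fold higher number from compound 2 to compound 3 (0.36 log units; beyond the scatter).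

Compound 4 `Cc1ccc2[nH]c(C(=O)N[C@H]3CN(S(=O)(=O)c4ccccc4)C[C@@H]3C(=O)N[C@H]3CCCNC3)cc2c1` has not been measured. It differs from compound 3 in one place: piperidin-3-yl in place of 1-methylpiperidin-3-yl on an amide-type nitrogen. Going by the values given here, two measured steps bear on this. a 2.3-fold higher number from compound 2 to compound 3 (0.36 log units; beyond the scatter) replaced a group carrying a hydrogen-bond donor with one carrying none; a 1.6-fold lower number from compound 1 to compound 2 (0.20 log units; within the scatter) went the other way, introducing a donor. Compound 4 reintroduces a donor, so a modest move downward is expected, a 1.6-fold lower number from compound 3 to compound 4 (0.22 log units; within the scatter). For compound 4 the estimated value is 14 uL/min, with a range from 8 uL/min to 25 uL/min.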

Compound 4, intrinsic clearance in a liver preparation (reported as CLH), per the amount of preparation that the assay uses: 7 uL/min
Compound 4: middle estimate off by 2.0-fold (0.30 log units), on the high side, outside the stated range (below it).
By their numbers in this assay, from the lowest: compounds 4, 2, 1 and 3 (each within the scatter of the next, the first and the last beyond it).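

Removing the ring methyl, so that piperidin-3-yl replaces 1-methylpiperidin-3-yl on the amide-type nitrogen, gives in this assay a 3.3-fold lower number from compound 3 to compound 4 (0.52 log units; beyond the scatter), the largest step yet seen at this position. The same group also separates from 2-(dimethylamino)ethyl, with a 2.3-fold lower number from compound 1 to compound 4 (0.36 log units; beyond the scatter), but not from (pyrrolidin-2-yl)methyl, with a 1.4-fold lower number from compound 2 to compound 4 (0.15 log units; within the scatter). Compound 2 and compound 4 both carry a hydrogen-bond donor in this group, although compound 2 itself stays within the scatter of compound 1, and nothing measured here explains the change.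

From the compounds shown here alone, the effect of removing the methyl rests on this single pair, so it remains open how an ethyl or acetyl group on the same ring nitrogen would compare. Also open, going by these compounds, is how a piperidin-4-yl or pyrrolidin-3-yl group would behave on the amide-type nitrogen.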